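The source may report more compounds than this note shows. Statements on the series, on what has been measured and on what is new or still open speak of the compounds shown alone.

Measured compounds:
Compound 1, `Cc1ccc(SCc2ccc(/C=C/C(=O)Nc3ccccc3N)cc2)cc1`, gives 31.2%.
Compound 2, `Nc1ccccc1NC(=O)c1ccc(CSc2nccc(C(F)(F)F)n2)cc1`, gives 80.1%.

Both numbers come from a functional assay on A-375 cells (Homo sapiens) for inhibition, read by CCK-8 assay, with a stated time of 72 h, tested at 8 uM; a higher number here means more inhibition of growth at the concentration tested, a lower number less inhibition of growth. Of the two values shown, compound 1 stands lowest; compound 2 lies a long way higher, and that gap is beyond the usual scatter of this assay. The compound still to be measured is compound 3, `Nc1ccccc1NC(=O)/C=C/c1ccc(CSc2ccc(C(F)(F)F)cn2)cc1`. It is built from compound 1 by one change: 5-(trifluoromethyl)pyridin-2-yl in place of 4-methylphenyl on a sulfur. The rest of the shared core, with its amide and the amino group on the aniline ring, is unchanged. Within the data shown here, no pair of measured compounds separated by a single change is available, so the size of this step must be judged from the structures alone. Because compound 2 reaches 80.1% with a fluorinated heteroaryl group on sulfur, a rise beyond the scatter is expected for the step of a number 23.8 percentage points higher from compound 1 to compound 3 (beyond the scatter). Compound 3 is estimated at 55%, within a range from 30% to 80%.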

Compound 3, percent growth inhibition at one concentration: 3.96%
Beside the measured number, compound 3's estimate is 51 percentage points above it, and the stated range ends above it.
By their numbers in this assay, from the lowest: compound 3; then compound 1; then compound 2.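

In this assay, the group on the sulfur clearly matters: putting 5-(trifluoromethyl)pyridin-2-yl in place of 4-methylphenyl gives a number 27.2 percentage points lower from compound 1 to compound 3 (beyond the scatter), so on this shared core the change lowers growth inhibition. Among these compounds, this is the first single-change reading at this position, and compound 2 differs from compound 3 in more than one place, so its high value cannot be read as a guide to this step. No supporting measurement is available to say why the value falls.

The compounds shown leave open whether the fall goes with the ring nitrogen, the trifluoromethyl group or the two together, as a plain pyridin-2-yl or a 4-(trifluoromethyl)phenyl group on the sulfur would help to separate them. From the compounds shown here alone, how a ring carrying an amine or a carboxylic acid would behave here also remains open.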